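The compounds below may be only part of what the source reports. "The series", "measured", "known", "first", "only" and "open" are said of these compounds alone.

In a functional assay on MCF7 cells (Homo sapiens) for inhibition, read by MTT assay, with a stated time of 48 h (on this read-out higher numbers stand for weaker inhibition and lower numbers for stronger inhibition), compound 1 `COc1ccc(/C=C2\SC(=O)N(CCNC(=O)Nc3c(C)n(C)n(-c4ccccc4)c3=O)C2=O)cc1` gives 5140 nM and compound 2 `COc1cc(/C=C2\SC(=O)N(CCNC(=O)Nc3c(C)n(C)n(-c4ccccc4)c3=O)C2=O)cc(OC)c1OC` gives 7580 nM. Compound 3 `COc1ccc(/C=C2\SC(=O)N(CC(=O)Nc3c(C)n(C)n(-c4ccccc4)c3=O)C2=O)cc1` gives 75600 nM, the highest of the three numbers and beyond the scatter from both others. Compound 4 `Cc1c(NC(=O)CN2C(=O)S/C(=C\c3ccc(Cl)cc3)C2=O)c(=O)n(-c2ccccc2)n1C` differs from compound 3 by a single swap, chloro in place of methoxy on an aromatic carbon. Going by the values given here, the only measured step that alters the groups on this aromatic ring is a 1.5-fold higher number from compound 1 to compound 2 (0.17 log units; within the scatter), and no measured compound carries chloro, so the evidence is thin. On that basis, no step beyond the scatter is expected in this assay, and the expected change is a 1.3-fold lower number from compound 3 to compound 4 (0.10 log units; within the scatter). For compound 4 the estimated value is 60000 nM, with an expected range from 20000 nM to 160000 nM.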

Compound 4, half-maximal inhibitory concentration: 42600 nM
Compound 4: the middle estimate sits 1.4-fold (0.15 log units) above what was measured, and the stated range covers the measured number.
By their numbers in this assay, from the lowest: compounds 1 and 2 (each within the scatter of the next); then compounds 4 and 3 (each within the scatter of the next).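

Putting 4-chlorophenyl in place of 4-methoxyphenyl gives a 1.8-fold lower number from compound 3 to compound 4 (0.25 log units; within the scatter) in this assay and so, at this aromatic carbon para to a large group, chloro and methoxy cannot be told apart. The earlier ring change, a 1.5-fold higher number from compound 1 to compound 2 (0.17 log units; within the scatter) on a different chain, also stayed within the scatter, so neither ring change shown separates its pair. Nothing measured here explains this result. As far as these compounds go, whether an amine or a carboxylic acid at this carbon would also stay within the scatter remains open. So does whether chloro would do the same on the chain of compound 1.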